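This account rests on a few compounds, and the source may have more. Where it says the series, first, only, none or still open, it means among the compounds named here.

Measured compounds:
Compound 1 `CCN(CC)CC(=O)OC1CC2(N(C)C)CC(c3ccccc3)C1C(c1ccccc1)C2` with 30100 nM
Compound 2 `CN(C)C12CC(OC(=O)CN3CCCC3)C(C(c3ccccc3)C1)C(c1ccccc1)C2` with 32700 nM

In an ADME assay on L6 cells (Rattus norvegicus) for cytotoxicity (a lower number here means a stronger inhibitor, a higher number a weaker inhibitor), compound 2 gives 32700 nM, level with compound 1 within the usual scatter of repeated measurements. Compound 3 `CN(C)C12CC(OC(=O)CN3CCCCC3)C(C(c3ccccc3)C1)C(c1ccccc1)C2` has not been measured yet. It keeps the shared core and differs from compound 2 at one place: piperidin-1-yl in place of pyrrolidin-1-yl on a saturated chain carbon bound to a carbonyl carbon. In short, piperidin-1-yl stands in place of pyrrolidin-1-yl on a saturated chain carbon bound to a carbonyl carbon.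

Within the data shown here, only one measured step bears on this, the exchange of a different group at the same place: a 1.1-fold higher number from compound 1 to compound 2 (0.04 log units; within the scatter). A single step is thin evidence, but it offers no reason to expect a step beyond the scatter in this assay. The expected step is a 1.2-fold lower number from compound 2 to compound 3 (0.07 log units; within the scatter), which would stay within the scatter. For compound 3 the estimate is 28000 nM, with an expected range from 14000 nM to 55000 nM for the measurement.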

Compound 3, half-maximal inhibitory concentration: 29300 nM
Beside the measured number, compound 3's estimate is 1.0-fold (0.02 log units) below it; the range from low to high includes it.
By their numbers in this assay, from the lowest: compounds 3, 1 and 2 (each within the scatter of the next).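

In this assay, piperidin-1-yl in place of pyrrolidin-1-yl on a saturated chain carbon bound to a carbonyl carbon gives a small step (a 1.1-fold lower number from compound 2 to compound 3 (0.05 log units; within the scatter)), and piperidin-1-yl in place of diethylamino gives another (a 1.0-fold lower number from compound 1 to compound 3 (0.01 log units; within the scatter)). Both steps lie within the scatter, so a six-membered ring now joins the five-membered ring and the open diethylamino group, and these three amines cannot be told apart here, which one earlier step could not show. Nothing available explains this lack of separation.

Still open, from the compounds shown here alone, is whether any group at this place would produce a step beyond the scatter. A morpholin-4-yl ring, a primary amine or a longer chain between the carbonyl and the nitrogen could test this.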